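Pyrrolyl enone series: carboxy for bromo on the aryl ring

The source may report more compounds than this note shows. Statements on the series, on what has been measured and on what is new or still open speak of the compounds shown alone.

Two members of the series have been measured in an assay for inhibition of cytochrome P450 1A1 (Homo sapiens), read by fluorescence, using microsomes, with a stated time of 10 min; a lower number here means a stronger inhibitor, a higher number a weaker inhibitor. Compound 1 `CCc1ccc(/C=C/C(=O)c2ccc[nH]2)o1` gives > 20000 nM in this assay, which is a limit of the assay rather than a number. Compound 2 `O=C(/C=C/c1ccc(Br)cc1)c1ccc[nH]1` gives > 20000 nM in this assay, again a limit and not a number. For the measured compounds named here, both measured values thus sit at the same ceiling (the limit of > 20000 nM in this assay, at which 2 of the 2 values shown sit), so no step between measured compounds can be read, and compound 2 stands only at that limit. Compound 3 `O=C(O)c1ccc(/C=C/C(=O)c2ccc[nH]2)cc1` differs from compound 2 by carboxy in place of bromo on an aromatic carbon. With both measured compounds at the limit (the limit of > 20000 nM in this assay, at which 2 of the 2 values shown sit), the series offers no basis for expecting a move into the measurable range. The step from compound 2 to compound 3 is expected to be a step that the limit leaves unreadable from compound 2 to compound 3, none beyond the scatter. Compound 3 is therefore estimated at 30000 nM, with a range from 8000 nM to 100000 nM, most likely reported once more as a limit.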

Compound 3, half-maximal inhibitory concentration: > 20000 nM
Compound 3 gave a limit, no number; the forecaster's own chance of this, stated with the estimate: 75%; the middle value lies beyond the limit too.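

Compound 3, like compound 2, stands only at a limit in this assay, so carboxy in place of bromo yields no readable step: the limit of > 20000 nM in this assay, at which 3 of the 3 values shown sit.

The compounds shown leave open whether any change to the shared core brings the series into the measurable range of this assay.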